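This account rests on a few compounds, and the source may have more. Where it says the series, first, only, none or still open, it means among the compounds named here.

Three compounds share one core and differ only in the group attached to a saturated chain carbon bound to an oxygen on an aromatic ring: compound 1 `CCOC(=O)c1cc(-c2cccc(OCc3cccc(C(F)(F)F)c3)c2)on1`, compound 2 `CCOC(=O)c1cc(-c2cccc(OCc3ccccc3Cl)c2)on1` and compound 3 `CCOC(=O)c1ccc(COc2cccc(-c3cc(C(=O)OCC)no3)c2)cc1`. In an ADME assay on Vero cells (Chlorocebus sabaeus) for cytotoxicity, with a stated time of 72 h (a lower number here means a stronger inhibitor, a higher number a weaker inhibitor), compound 1 reaches only the limit of the test, > 128000 nM. Compound 2 likewise gives only a limit in this assay, > 128000 nM. Compound 3 also stops at a limit in this assay, > 128000 nM. So compound 2 stands where every value so far stands, at the limit, with no number to compare against (the limit of > 128000 nM in this assay, at which 3 of the 3 values shown sit).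

Compound 4 `CCOC(=O)c1cc(-c2cccc(OCc3ccc(F)c(F)c3F)c2)on1` has not yet been measured in this assay. It differs from compound 2 in one place (2,3,4-trifluorophenyl in place of 2-chlorophenyl on a saturated chain carbon bound to an oxygen on an aromatic ring). Going by the values given here, since each measured value sits at the limit, no step in this assay beyond the usual scatter is expected, and the step from compound 2 to compound 4 is estimated as a number no higher from compound 2 to compound 4 (the limit leaves the size open). Compound 4 is therefore expected to give about 128000 nM in this assay, estimated to lie between 64000 nM and 256000 nM, most likely again only as a limit.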

Compound 4, half-maximal inhibitory concentration: > 128000 nM
Compound 4: a limit, no number; the forecaster's own chance of this, stated with the estimate: 85%; the middle value sits exactly at the limit.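

In this assay, going by these compounds alone, compound 2 and compound 4 both give only a limit, so no step between them can be read: the limit of > 128000 nM in this assay, at which 4 of the 4 values shown sit. The compounds shown leave open how strongly, if at all, any of them inhibits the cells, and whether changing the group on the shared core alters that.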